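The source may report more compounds than this note shows. Statements on the series, on what has been measured and on what is new or still open speak of the compounds shown alone.

Measured compounds in a functional assay on HepG2 cells (Homo sapiens) for cytotoxicity, read by MTT assay, with a stated time of 48 h; on this read-out lower numbers stand for stronger inhibition and higher numbers for weaker inhibition:
- compound 1, `COC(=O)/C=C/c1ccc2c(c1)C(=O)C(=O)N2Cc1ccc(Cl)c(Cl)c1`: 160 nM
- compound 2, `COC(=O)/C=C/c1ccc2c(c1)C(=O)C(=O)N2Cc1ccc(OC)cc1`: 30 nM
- compound 3, `COC(=O)/C=C/c1ccc2c(c1)C(=O)C(=O)N2Cc1cc(C)cc(C)c1`: 150 nM

Compound 3 stands second highest of the three numbers; its nearest neighbour is compound 1, with a 1.1-fold lower number from compound 1 to compound 3 (0.03 log units; within the scatter), and its furthest is compound 2, with a 5.0-fold higher number from compound 2 to compound 3 (0.70 log units; beyond the scatter). All three measured compounds share the same core and differ only in the group on the saturated chain carbon bound to the amide-type nitrogen in the ring.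

Compound 4, `CCN1C(=O)C(=O)c2cc(/C=C/C(=O)OC)ccc21`, is not yet measured. Its difference from compound 3 is methyl in place of 3,5-dimethylphenyl on a saturated chain carbon bound to an amide-type nitrogen in a ring.

Going by the values given here, none of the measured steps bears directly on this change: each of them exchanges one aryl group for another on that carbon (a 5.3-fold lower number from compound 1 to compound 2 (0.73 log units; beyond the scatter), a 1.1-fold lower number from compound 1 to compound 3 (0.03 log units; within the scatter), a 5.0-fold higher number from compound 2 to compound 3 (0.70 log units; beyond the scatter)), whereas compound 4 gives up the aromatic ring altogether in favour of a single carbon. The measured series shows that the identity of the aryl group shifts the number by at most a modest step, with the exchange between compound 1 and compound 3 staying within the scatter. Among the compounds with values here, removing the ring is a larger structural change than any of those, so a shift beyond the scatter toward a higher number is expected, but with wide uncertainty because no measured pair tests it. The step is estimated as a 3.0-fold higher number from compound 3 to compound 4 (0.48 log units; beyond the scatter). Compound 4 is therefore expected to give about 450 nM in this assay, within a range from 120 nM to 1700 nM.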

Compound 4, half-maximal inhibitory concentration: 400 nM
Beside the measured number, compound 4's estimate is 1.1-fold (0.05 log units) above it; the range from low to high includes it.
By their numbers in this assay, from the lowest: compound 2; then compounds 3 and 1 (each within the scatter of the next); then compound 4.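

In this assay, methyl in place of an aryl group on a saturated chain carbon bound to an amide-type nitrogen in a ring still leaves a measurable number, but the size of the step depends on which aryl group leaves: it is modest for 3,5-dimethylphenyl (a 2.7-fold higher number from compound 3 to compound 4 (0.43 log units; beyond the scatter)) and for 3,4-dichlorophenyl (a 2.5-fold higher number from compound 1 to compound 4 (0.40 log units; beyond the scatter)), and large for 4-methoxyphenyl (a 13-fold higher number from compound 2 to compound 4 (1.12 log units; beyond the scatter)). All three of these steps lie beyond the scatter, so compound 4 is the weakest of the four and each aryl group tested gives a lower number than methyl at this position, with no compound shown going against this. Nothing shown accounts for the size of these steps or for the difference between them.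

Still open, going by these compounds, is whether a cyclohexyl ring or a longer chain such as butyl on that carbon would give a number close to that of compound 2 or close to that of compound 4. Also open, on these data alone, is how a carboxylic acid in place of the methyl ester would change the number with the 4-methoxyphenyl group held in place.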